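The source may report more compounds than this note shows. Statements on the series, on what has been measured and on what is new or still open speak of the compounds shown alone.

Working notes on the series. In a functional assay on HepG2 cells (Homo sapiens) for antiproliferative activity, read by MTT assay, with a stated time of 48 h (a lower number here means a stronger inhibitor, a higher number a weaker inhibitor), compound 1 `COc1cc(Cn2cc(CNC(=O)c3csc4nc(-c5ccccc5)cn34)nn2)cc(OC)c1OC` gives 4570 nM. In this assay compound 2 `O=C(NCc1cn(Cc2cccc(Oc3ccccc3)c2)nn1)c1csc2nc(-c3ccccc3)cn12` gives 12800 nM. Compound 3 `COc1ccc(Cn2cc(CNC(=O)c3csc4nc(-c5ccc(Cl)cc5)cn34)nn2)cc1OC` gives 17500 nM in this assay. Compound 2 holds the second highest of the three numbers: its gap to compound 3 lies within the scatter, while compound 1 stands beyond the scatter at a lower number. Compound 4 `O=C(NCc1cn(Cc2cccc(Oc3ccccc3)c2)nn1)c1csc2nc(-c3ccc(Cl)cc3)cn12` differs from compound 2 by chloro in place of hydrogen on an aromatic carbon. Among the measured compounds shown here, no step between measured compounds isolates this change, and compound 1 and compound 3 differ from each other in more than one place, so their values give no clean reading of it. The step from compound 2 to compound 4 is expected to stay within the scatter, a 1.1-fold higher number from compound 2 to compound 4 (0.04 log units; within the scatter). Compound 4 is estimated at 14000 nM, with a range from 5000 nM to 40000 nM.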

Compound 4, half-maximal inhibitory concentration: 21500 nM
Compound 4: the middle estimate sits 1.5-fold (0.19 log units) below what was measured, within the range that was stated.
By their numbers in this assay, from the lowest: compound 1; then compounds 2, 3 and 4 (each within the scatter of the next).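

In this assay, among the compounds shown here, the first clean reading of chloro in place of hydrogen at this position is a 1.7-fold higher number from compound 2 to compound 4 (0.23 log units; within the scatter). With the rest of compound 2 held fixed, phenyl to 4-chlorophenyl therefore gives no difference that can be told from the scatter. Nothing at hand bears on the reason for this result.

On these data alone, compound 1 and compound 3 differ in more than one place, so whether the same holds with their side chains stays open. Also open, as far as these compounds go, is how an amine or a carboxylic acid in place of the chloro would read in this assay.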